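Swapping benzoyl for acetyl on a tetrahydroquinoline amide

The source may hold more compounds than are shown below. What is called first, only, known or untested is meant among the compounds shown, and "the series" means these compounds.

Measured so far in a functional assay on HCT-15 cells (Homo sapiens) for cytotoxicity, read by sulforhodamine B assay, with a stated time of 72 h; on this read-out lower numbers stand for stronger inhibition of growth and higher numbers for weaker inhibition of growth:
compound 1 `CC(=O)N1c2ccccc2CCC1C(=O)Nc1ccccc1O` gives 54500 nM.
compound 2 `CCC(=O)N1c2ccccc2CCC1C(=O)Nc1ccccc1C(F)(F)F` gives > 80000 nM.
compound 3 `O=C(Nc1ccccc1C(F)(F)F)C1CCc2ccccc2N1C(=O)c1ccccc1` gives 6500 nM.

The value of compound 2 is only a limit of the assay, not a number. Among the two numbers that exist, compound 3 has the lower one, and compound 1 sits well apart from it with a number beyond the scatter. Going by the values given here, the one step that can be read directly, an at least 12-fold lower number from compound 2 to compound 3 (1.09 log units; beyond the scatter), shows that a phenyl on the carbonyl carbon instead of a small alkyl chain goes with a large drop in this assay; the size of that step is bounded by the limit of > 80000 nM in this assay, at which 1 of the 3 values shown sits.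

Compound 4 `CC(=O)N1c2ccccc2CCC1C(=O)Nc1ccccc1C(F)(F)F` is the acetyl partner of compound 3: methyl in place of phenyl on a carbonyl carbon. This undoes the kind of change that made compound 3 stand out, so a large rise back toward the values of compounds 1 and 2 is expected. Compound 4 is therefore estimated at 70000 nM, with a range from 20000 nM to 200000 nM. The step this implies, an 11-fold higher number from compound 3 to compound 4 (1.03 log units; beyond the scatter), is expected to be large and upward, with a real chance that the assay again reports only a limit rather than a number.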

Compound 4, concentration for 50% growth inhibition: > 80000 nM
Compound 4: no number, only a limit; the forecaster's own chance of this, stated with the estimate: 45%; middle value at least 1.1-fold (0.05 log units) away from the limit.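

Read directly, the change from benzoyl to acetyl on this carbonyl carbon, with the trifluoromethyl group kept in place, goes with an at least 12-fold higher number from compound 3 to compound 4 (1.09 log units; beyond the scatter); among the compounds shown, only the phenyl version gives a low value, and neither small group, ethyl in compound 2 or methyl in compound 4, does. In this assay compound 4 gives > 80000 nM, which is a limit of the assay and not a number, so the step from compound 3 gives only a floor, and the step from compound 2, also a limit, cannot be read: the limit of > 80000 nM in this assay, at which 2 of the 4 values shown sit. With acetyl kept, trifluoromethyl in place of hydroxy on the aromatic carbon goes with an at least 1.4-fold higher number from compound 1 to compound 4 (0.16 log units; that floor lies within the scatter), and since that floor lies within the scatter, this comparison shows no firm change.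

From the compounds shown here alone, it remains open how far compound 2 and compound 4 truly lie from compound 3, and whether the benzoyl group would give a similar drop with hydroxy in place of trifluoromethyl. Also open, going by these compounds, is what a longer chain, or a phenyl ring carrying an amine or a carboxylic acid, would do on this carbonyl carbon.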